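From fluoro to methoxy on a weak inhibitor

The source may hold more compounds than are shown below. What is called first, only, known or untested is meant among the compounds shown, and "the series" means these compounds.

Going by the values given here, in a functional assay on MDA-MB-231 cells (Homo sapiens) for antiproliferative activity, read by MTT assay, with a stated time of 24 h (a lower number here means a stronger inhibitor, a higher number a weaker inhibitor), compound 2 `O=C(O)CC(NC(=O)c1ccc(F)cc1)c1ccc(Cl)cc1Cl` gives 58300 nM as the only actual number so far. Compound 1 `COc1ccc(C(=O)NC(CC(=O)O)c2ccc(C(C)(C)C)cc2)cc1` carries the 4-methoxyphenyl group and gives > 100000 nM as a limit of this assay and not a number. Among the compounds with values here, the single change methoxy in place of fluoro on an aromatic carbon puts methoxy in place of fluoro on an aromatic carbon, para to a large group, and turns compound 2 into compound 3 `COc1ccc(C(=O)NC(CC(=O)O)c2ccc(Cl)cc2Cl)cc1` while the rest stays.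

Within the data shown here, no measured pair isolates this change. Compound 2 at 58300 nM is the closest guide, so a small step in this assay is expected, perhaps none beyond the scatter. Compound 1 with its limit of > 100000 nM shares the methoxy group, so any shift is expected toward a weaker result. The estimated step of a 1.1-fold higher number from compound 2 to compound 3 (0.05 log units; within the scatter) stays modest for that reason. For compound 3 the expected value is 65000 nM with an estimated range from 30000 nM to 100000 nM around it.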

Compound 3, half-maximal inhibitory concentration: > 100000 nM
Compound 3 gave a limit, no number; the forecaster's own chance of this, stated with the estimate: 30%; at least 1.5-fold (0.18 log units) between middle value and limit.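

In this assay compound 3 gives > 100000 nM, which is a limit of the assay and not a number. Going from 4-fluorophenyl to 4-methoxyphenyl at this position gives an at least 1.7-fold higher number from compound 2 to compound 3 (0.23 log units; that floor lies within the scatter), so this change brings no measurable gain in activity, though the floor of that step does not separate the two compounds beyond the usual scatter. The true size of the step cannot be read because of where the values sit: the limit of > 100000 nM in this assay, at which 2 of the 3 values shown sit.

From the compounds shown here alone, what an amine or a hydroxyl group at this same position would do remains open. The compounds shown also leave open whether any replacement for fluoro here can give a lower number than compound 2.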